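The compounds below may be only part of what the source reports. "The series", "measured", "known", "first", "only" and "open" are said of these compounds alone.

Measured compounds in a functional assay on DU-145 cells (Homo sapiens) for cytotoxicity, read by sulforhodamine B assay, with a stated time of 48 h; on this read-out lower numbers stand for stronger inhibition of growth and higher numbers for weaker inhibition of growth:
Compound 1 `N#Cc1ccc(Nc2nc(Oc3ccnc4ccccc34)nc(N3CCN(c4ccccc4Cl)CC3)n2)cc1C(F)(F)F` gives > 100000 nM, which is a limit of the assay.
Compound 2 `N#Cc1ccc(Nc2nc(Oc3ccnc4ccccc34)nc(N3CCN(c4ccccc4)CC3)n2)cc1C(F)(F)F` gives > 100000 nM, again a limit.
Compound 3 `COc1ccc(N2CCN(c3nc(Nc4ccc(C#N)c(C(F)(F)F)c4)nc(Oc4ccnc5ccccc45)n3)CC2)cc1` gives > 100000 nM, also a limit.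

Compound 3 stands at the limit of the assay, as do the two other measured compounds, so no numbered position can be given to it. The steps from compound 1 to compound 2 a step that the two limits leave unreadable from compound 1 to compound 2, from compound 1 to compound 3 a step that the two limits leave unreadable from compound 1 to compound 3 and from compound 2 to compound 3 a step that the two limits leave unreadable from compound 2 to compound 3 are all unreadable, since every value sits at the same limit (the limit of > 100000 nM in this assay, at which 3 of the 3 values shown sit).

Compound 4 `N#Cc1ccc(Nc2nc(Oc3ccnc4ccccc34)nc(N3CCN(c4cccc(Cl)c4Cl)CC3)n2)cc1C(F)(F)F` differs from compound 3 in one place: 2,3-dichlorophenyl in place of 4-methoxyphenyl on an amine nitrogen in a ring. Going by the values given here, none of the measured steps can be read for size, so none of them shows a direction, and no change beyond the scatter can be foreseen. Compound 4 is therefore expected to remain near the limit of the assay, with the estimated step from compound 3 to compound 4 being a step that the limit leaves unreadable from compound 3 to compound 4. For compound 4 the estimate is 150000 nM, within a range from 50000 nM to 500000 nM, most probably reported as a limit.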

Compound 4, concentration for total growth inhibition: > 100000 nM
Compound 4: only a limit was reported; the forecaster's own chance of this, stated with the estimate: 85%; the middle value lies beyond the limit too.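

Going by these compounds alone, no step from compound 1, compound 2 or compound 3 to compound 4 can be read, since all four compounds sit at the same limit: the limit of > 100000 nM in this assay, at which 4 of the 4 values shown sit. The compounds shown leave open whether any group on the amine nitrogen in the ring would give a measurable number in this assay at all.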